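Fluoro to methoxy on an aromatic carbon

The source may hold more compounds than are shown below. What is called first, only, known or untested is meant among the compounds shown, and "the series" means these compounds.

Of the compounds shown here, two in this small series have been measured so far. In a functional assay on MCF7 cells (Homo sapiens) for antiproliferative activity, read by MTT assay, with a stated time of 48 h (a higher number here means a weaker inhibitor, a lower number a stronger inhibitor), compound 1 (`CCOC(=O)/C(=C/c1ccccc1)CN1C(=O)[C@@H](OC)[C@H]1c1ccc(Cl)cc1`) gives 12700 nM and compound 2 (`COC(=O)/C(=C/c1ccccc1)CN1C(=O)[C@@H](OC)[C@H]1c1ccc(F)cc1`) gives 15600 nM with the two numbers lying within the usual scatter of each other. Compound 2 therefore cannot be separated from compound 1 on these data, and neither can be ranked as the better inhibitor. The next compound to be tested is compound 3 (`COC(=O)/C(=C/c1ccccc1)CN1C(=O)[C@@H](OC)[C@H]1c1ccc(OC)cc1`) and it departs from compound 2 in one place only: methoxy in place of fluoro on an aromatic carbon with methoxy in place of fluoro on an aromatic carbon, para to a large group. Among the measured compounds shown here, no measured pair shows a change made in one place, so no earlier step gives a guide to the size of this one. The estimated step of a 1.1-fold lower number from compound 2 to compound 3 (0.05 log units; within the scatter) is expected to stay within the scatter, with no firm direction. This expectation takes compound 2 at 15600 nM as its starting point. For compound 3 the expected value is 14000 nM with an estimated range from 5000 nM to 35000 nM in a single measurement.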

Compound 3, half-maximal inhibitory concentration: 11600 nM
Compound 3: the middle estimate sits 1.2-fold (0.08 log units) above what was measured; low and high end bracket the measured number.
By their numbers in this assay, from the lowest: compounds 3, 1 and 2 (each within the scatter of the next).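

In this assay, among the compounds shown here, replacing fluoro with methoxy, para to a large group on a six-membered aromatic ring of carbon only, gives a 1.3-fold lower number from compound 2 to compound 3 (0.13 log units; within the scatter), the first change in one place that can be read. This position therefore carries either group, and the 2 heavy atoms and hydrogen-bond acceptor of methoxy in place of the single fluorine leave the result unresolved from that of the fluoro compound, so this step sets no direction for the 4-fluorophenyl to 4-methoxyphenyl change. Nothing measured here bears on what lies behind this result.

The compounds shown leave open whether any group at this position can move the number beyond the scatter, since only fluoro and methoxy have been compared here in a single-place change, and compound 1 differs from compound 3 in more than one place. An amine, a carboxylic acid or a longer alkoxy chain at this position would test how far that tolerance extends.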